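A Triazole in Place of the Carboxylic Acid

The source may hold more compounds than are shown below. What is called first, only, known or untested is meant among the compounds shown, and "the series" means these compounds.

Compound 3 `CCC(C)(C)Cc1c[nH]c(CCc2ccc(-c3ccccc3OCC(=O)O)cc2)n1` gives 103 nM in an assay on isolated protein for binding affinity to Bombesin receptor subtype-3 (Homo sapiens) (a higher number here means a weaker inhibitor, a lower number a stronger inhibitor), the second highest of the three numbers shown. Compound 1 `CCC(C)(C)Cc1c[nH]c(CCc2ccc(-c3ccccc3O)cc2)n1` gives 31 nM, and compound 2 `O=C1NC(=O)C(c2ccccc2-c2ccc(CCC3N=CC(CC4CCCC4)=N3)cc2)S1` gives 287 nM. Compound 4 `CCC(C)(C)Cc1c[nH]c(CCc2ccc(-c3ccccc3OCc3ncn[nH]3)cc2)n1` differs from compound 3 by 1H-1,2,4-triazol-5-yl in place of carboxy on a saturated chain carbon bound to an oxygen on an aromatic ring. Among the measured compounds shown here, the only measured step that touches this position is a 3.3-fold higher number from compound 1 to compound 3 (0.52 log units; beyond the scatter), a modest loss on attaching the carboxymethyl to the oxygen. For the measured compounds named here, no measured step covers the triazole itself, so the size of a 1.6-fold lower number from compound 3 to compound 4 (0.20 log units; within the scatter) is expected to stay small, with a slight lean toward a lower number. Compound 4 is therefore estimated at 65 nM, within a range of 20 nM to 200 nM.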

Compound 4, half-maximal inhibitory concentration: 22 nM
Estimate against measurement, compound 4: 3.0-fold (0.47 log units) above; the measured number falls inside the stated range.
By their numbers in this assay, from the lowest: compounds 4 and 1 (each within the scatter of the next); then compound 3; then compound 2.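

In this assay, 1H-1,2,4-triazol-5-yl in place of carboxy gives a 4.7-fold lower number from compound 3 to compound 4 (0.67 log units; beyond the scatter) and shows that this saturated chain carbon responds to the group it carries, not merely to a substituent on the oxygen. Adding (1H-1,2,4-triazol-5-yl)methyl in place of hydrogen gives a 1.4-fold lower number from compound 1 to compound 4 (0.15 log units; within the scatter) and, unlike carboxymethyl, costs nothing beyond the scatter. Nothing available explains the gap between these two groups. As far as these compounds go, whether a tetrazole or an amide at this carbon, or a longer chain carrying the triazole, would preserve the number remains open.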